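Flipping One Ring Stereocentre in a Metabolic Stability Series

The source may hold more compounds than are shown below. What is called first, only, known or untested is meant among the compounds shown, and "the series" means these compounds.

Compound 1, `CC(=O)N[C@@H]1CCCc2c1cncc2N1C(=O)c2ccc(Cl)cc2[C@H]1C`, gives 43.5 mL/min/kg in an ADME assay on microsomes from liver (Mus musculus) for metabolic stability, read by LC-MS, using NADPH, with stated times of 10 min and 30 min; a lower number here means slower removal, a higher number faster removal of the compound.
Compound 2, `CCC(=O)N[C@@H]1CCCc2c1cncc2N1C(=O)c2ccc(Cl)cc2[C@@H]1C`, gives only a limit of the assay, < 20.2 mL/min/kg, in this assay.
Compound 3, `CCC(=O)N[C@@H]1CCCc2c1cncc2N1C(=O)c2ccc(Cl)cc2[C@@H]1CC`, likewise gives only a limit, < 20.2 mL/min/kg, in this assay.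

For the measured compounds named here, compound 2 thus stands at the limit (the limit of < 20.2 mL/min/kg in this assay, at which 2 of the 3 values shown sit), and the one step recorded from it, a step that the two limits leave unreadable from compound 2 to compound 3, is unreadable for the same reason. Compound 4, `CCC(=O)N[C@@H]1CCCc2c1cncc2N1C(=O)c2ccc(Cl)cc2[C@H]1C`, differs from compound 2 by the two compounds have the same atoms and bonds and differ only in configuration as drawn: 1 of 2 stereo elements differ; a stereocentre at a saturated ring carbon is drawn S in compound 2 and R in compound 4. Going by the values given here, no measured step covers a change in configuration alone; compound 1 shares the configuration drawn for compound 4 but carries the shorter acetamide, so no single change separates it from compound 2. Compound 4 is therefore expected in this assay at 28 mL/min/kg, between 14 mL/min/kg and 56 mL/min/kg. This estimate amounts to an expected step of an at least 1.3-fold higher number from compound 2 to compound 4 (0.14 log units; that floor lies within the scatter).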

Compound 4, clearance: 45.6 mL/min/kg
Compound 4: the middle estimate sits 1.6-fold (0.21 log units) below what was measured; the measured number falls inside the stated range.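

Inverting this one stereocentre at a saturated ring carbon gives an at least 2.2-fold higher number from compound 2 to compound 4 (0.35 log units; beyond the scatter) in this assay, the first readable step in the series. The configuration alone accounts for this difference: the fact that compounds 2 and 4 differ only in the configuration as drawn By contrast, the methyl in place of hydrogen on a saturated chain carbon bound to a carbonyl carbon gives a 1.0-fold higher number from compound 1 to compound 4 (0.02 log units; within the scatter), which stays within the scatter.

From the compounds shown here alone, the full size of the configuration step remains open because compound 2 gives only a limit: the limit of < 20.2 mL/min/kg in this assay, at which 2 of the 4 values shown sit. Also open is whether the configuration matters equally with a longer chain or a carboxylic acid in place of the amide's chain.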